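Carbonate ester variants: stability in buffer

This account rests on a few compounds, and the source may have more. Where it says the series, first, only, none or still open, it means among the compounds named here.

Compound 1, `CCOC(=O)C1=C(S[C@@H]2CN[C@H](C(=O)Nc3cccc(C(=O)O)c3)C2)[C@H](C)[C@@H]2[C@@H]([C@@H](C)O)C(=O)N12`, gives > 95% in a physicochemical assay for metabolic stability, read by LC-MS, in phosphate buffer, with a stated time of 3 h, at pH 7.4, tested at 50 uM (on this read-out lower numbers stand for a less stable compound and higher numbers for a more stable compound), which is a limit of the assay rather than a number. Compound 2, `CCC(CC)C(=O)OCOC(=O)C1=C(S[C@@H]2CN[C@H](C(=O)Nc3cccc(C(=O)O)c3)C2)[C@H](C)[C@@H]2[C@@H]([C@@H](C)O)C(=O)N12`, gives > 95% in this assay, again a limit. Compound 3, `COC(=O)OCOC(=O)C1=C(S[C@@H]2CN[C@H](C(=O)Nc3cccc(C(=O)O)c3)C2)[C@H](C)[C@@H]2[C@@H]([C@@H](C)O)C(=O)N12`, gives > 95% in this assay, also a limit.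

Compound 3 thus stands at the limit, as shown by the limit of > 95% in this assay, at which 3 of the 3 values shown sit. Compound 4, `C[C@@H](O)[C@H]1C(=O)N2C(C(=O)OCOC(=O)OC(C)(C)C)=C(S[C@@H]3CN[C@H](C(=O)Nc4cccc(C(=O)O)c4)C3)[C@H](C)[C@H]12`, differs from it by tert-butyl in place of methyl on an oxygen next to a carbonyl group. The measured steps that touch the same part of the molecule are all unreadable: a step that the two limits leave unreadable from compound 1 to compound 2, a step that the two limits leave unreadable from compound 1 to compound 3 and a step that the two limits leave unreadable from compound 2 to compound 3. None of them gives a size, so no step beyond the scatter can be read from them in this assay in either direction. Compound 4 is therefore expected to sit at the limit as well, with an estimated step that the limit leaves unreadable from compound 3 to compound 4. The estimate for compound 4 in this assay is 97%, between 88% and 100%.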

Compound 4, percent of the compound remaining: > 95%
Compound 4: no number, only a limit; the forecaster's own chance of this, stated with the estimate: 80%; the middle value lies beyond the limit too.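

Compound 4 joins compound 1, compound 2 and compound 3 at the same limit, so no step among these four compounds can be read in this assay: the limit of > 95% in this assay, at which 4 of the 4 values shown sit. The compounds shown leave open whether the groups that differ among them affect stability in this buffer at all.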